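Cyano to chloro on two inactive amide scaffolds

The source may report more compounds than this note shows. Statements on the series, on what has been measured and on what is new or still open speak of the compounds shown alone.

compound 1 `N#Cc1cccc(C(=O)N[C@H]2CCC[C@H](NC(=O)c3ccccn3)C2)c1`: > 10000 nM
compound 2 `O=C(N[C@H]1CCC[C@H](NC(=O)c2ccccn2)C1)c1cccc(Cl)c1`: > 10000 nM
compound 3 `N#Cc1cccc(C(=O)N[C@@H]2CCC[C@@H](C(=O)Nc3ccccn3)C2)c1`: > 10000 nM

In a functional assay on HEK293 cells for antagonist activity at metabotropic glutamate receptor 5 (Homo sapiens), read by FLIPR and calcium flux (on this read-out higher numbers stand for weaker inhibition and lower numbers for stronger inhibition), compound 1 reaches only the limit of the assay, > 10000 nM. Compound 2 also reaches only that limit, > 10000 nM. Compound 2 differs from compound 1 by chloro in place of cyano on an aromatic carbon. The resulting step, a step that the two limits leave unreadable from compound 1 to compound 2, cannot be sized because both values sit at the limit of > 10000 nM in this assay, at which 3 of the 3 values shown sit.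

Compound 3 has the same atoms as compound 1 joined differently; the difference between the two cores is not broken down here. In this assay compound 3 likewise gives only a limit, > 10000 nM.

Compound 4 `O=C(N[C@@H]1CCC[C@@H](C(=O)Nc2ccccn2)C1)c1cccc(Cl)c1` has not yet been tested. It differs from compound 3 by chloro in place of cyano on an aromatic carbon, the same change at the same place as before. The step that the limit leaves unreadable from compound 3 to compound 4 is expected to stay unreadable, resting on a step that the two limits leave unreadable from compound 1 to compound 2. Compound 4 is estimated at 20000 nM, most likely a limit again, within 8000 nM to 60000 nM.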

Compound 4, half-maximal inhibitory concentration: 5000 nM
Compound 4: the middle estimate sits 4.0-fold (0.60 log units) above what was measured; measured number below the stated range.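

In this assay, going by these compounds, chloro in place of cyano on an aromatic carbon gives an at least 2.0-fold lower number from compound 3 to compound 4 (0.30 log units; that floor lies within the scatter); this is only a floor, so the true size of the step is unknown, and the floor itself lies within the usual scatter. The result therefore hints at a change on this core but does not establish one. Whether the change carries from one core to the other cannot be judged, because the same swap on the core of compound 1 cannot be read, with both values being limits: the limit of > 10000 nM in this assay, at which 3 of the 4 values shown sit.

On these data alone, it remains open how either core would respond to a different group on that aromatic carbon, such as an amine or a carboxylic acid. Also open, as far as these compounds go, is how far below the limit compound 3 truly lies.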